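The source may report more compounds than this note shows. Statements on the series, on what has been measured and on what is new or still open speak of the compounds shown alone.

In a functional assay on T47D cells (Homo sapiens) for cytotoxicity, read by CCK-8 assay and cell counting, with stated times of 4 h and 2 days (a higher number here means a weaker inhibitor, a lower number a stronger inhibitor), compound 1 `Oc1cccc(-c2cc(-c3ccccc3Cl)cc(-c3ccsc3)n2)c1` gives 680 nM and compound 2 `Oc1cccc(-c2cc(-c3cccc(Cl)c3)cc(-c3cccs3)n2)c1` gives 680 nM, so the two stand level at the digits shown. Compound 3 `Oc1cccc(-c2cc(-c3cccc(Cl)c3)cc(-c3ccsc3)n2)c1` has not yet been measured. It carries thiophen-3-yl in place of thiophen-2-yl on an aromatic carbon. Among the compounds with values here, no measured step between these compounds is available as a guide. Compound 1, which also carries thiophen-3-yl, gives 680 nM, and on that basis no step beyond the scatter is expected in this assay, in either direction. The expected change is a 1.0-fold lower number from compound 2 to compound 3 (0.02 log units; within the scatter). For compound 3 the estimated value is 650 nM, within an expected range of 280 nM to 1500 nM.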

Compound 3, half-maximal inhibitory concentration: 680 nM
Compound 3: the middle estimate sits 1.0-fold (0.02 log units) below what was measured; low and high end bracket the measured number.
By their numbers in this assay, from the lowest: compounds 1, 2 and 3 (each within the scatter of the next).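

In this assay, thiophen-3-yl in place of thiophen-2-yl next to the ring nitrogen gives no change at the digits printed from compound 2 to compound 3 (within the scatter), so the attachment point of this thiophene makes no readable difference with 3-chlorophenyl on the core. 3-chlorophenyl in place of 2-chlorophenyl gives no change at the digits printed from compound 1 to compound 3 (within the scatter), so this swap is likewise flat with thiophen-3-yl in place. No available data explain either result. As far as these compounds go, both swaps keep a thiophene and a chlorophenyl group, so the effect of a carboxylic acid or an aminomethyl group at the thiophene position remains open.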